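A Methoxyphenyl Replaces a Chlorophenyl on the Amide Nitrogen

The source may report more compounds than this note shows. Statements on the series, on what has been measured and on what is new or still open speak of the compounds shown alone.

Three acids share one core and differ only in the aryl group attached to one amide nitrogen. Compound 1 `Cc1cccc(NC(=O)C(=O)Nc2ccc(OCC(=O)O)c(F)c2)c1` gives 36.3% in a functional assay on CHO cells for agonist activity at Free fatty acid receptor 1 (Homo sapiens), read by FLIPR, tested at 300 nM; on this read-out higher numbers stand for a stronger effect at the one concentration tested and lower numbers for a weaker effect. Compound 2 `O=C(O)COc1ccc(NC(=O)C(=O)Nc2ccccc2Cl)cc1F` gives 27.9% in this assay, and compound 3 `O=C(O)COc1ccc(NC(=O)C(=O)Nc2cccc(Cl)c2)cc1F` gives 33.7%. Compound 3 thus stands second highest of the three numbers, with compound 1 nearest and compound 2 furthest, and both gaps lie within the scatter of this assay.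

Compound 4 `COc1ccccc1NC(=O)C(=O)Nc1ccc(OCC(=O)O)c(F)c1` has not yet been measured. It differs from compound 3 in a single place: 2-methoxyphenyl in place of 3-chlorophenyl on an amide-type nitrogen.

Within the data shown here, three measured steps bear on this change. Exchanging the 2-chlorophenyl for the 3-chlorophenyl gave a number 5.8 percentage points higher from compound 2 to compound 3 (within the scatter), exchanging methyl for chloro on the ring gave a number 2.6 percentage points lower from compound 1 to compound 3 (within the scatter), and exchanging the 3-methylphenyl for the 2-chlorophenyl gave a number 8.4 percentage points lower from compound 1 to compound 2 (within the scatter). Every exchange of this aryl group so far has stayed within the scatter, so the 2-methoxyphenyl is expected to behave the same way. Compound 4 is therefore expected to move by a number 2.7 percentage points lower from compound 3 to compound 4 (within the scatter) in this assay. For compound 4 the estimated value in this assay is 31%, with a range from 15% to 47%.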

Compound 4, a percentage reported as activity, at one concentration (the size of the read-out at that concentration, not a potency): 19.9%
Beside the measured number, compound 4's estimate is 11.1 percentage points above it, and the stated range covers the measured number.
By their numbers in this assay, from the lowest: compounds 4, 2, 3 and 1 (each within the scatter of the next, the first and the last beyond it).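

Among these compounds, two exchanges at this amide-type nitrogen now leave the scatter in this assay for the first time: 2-methoxyphenyl in place of 3-chlorophenyl gives a number 13.8 percentage points lower from compound 3 to compound 4 (beyond the scatter) and 2-methoxyphenyl in place of 3-methylphenyl gives a number 16.4 percentage points lower from compound 1 to compound 4 (beyond the scatter), so the read-out at this position does respond to the choice of aryl group, if only modestly. Methoxy in place of chloro on the aromatic carbon tells a different story, with a number 8 percentage points lower from compound 2 to compound 4 (within the scatter) and no separation between the two, so the 2-methoxyphenyl group stands apart from the groups of compound 1 and compound 3 but not from the group of compound 2. Nothing in the data given here explains this difference.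

Going by these compounds, with only four compounds, it remains open whether the loss belongs to the methoxy group itself or to the particular aryl group that carries it. On these data alone, it is also open how a phenyl ring bearing an amine, a carboxylic acid or a longer ether chain such as ethoxy would read at this nitrogen, and whether any aryl group here could raise the number beyond the scatter.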